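Squalene monooxygenase series: formyl replacing carbamoyl on the arylsilane

This account rests on a few compounds, and the source may have more. Where it says the series, first, only, none or still open, it means among the compounds named here.

Measured so far:
compound 1 `CCN(C/C=C/C#CC(C)(C)C)Cc1cccc(OC[Si](C)(C)c2ccc(Cl)cc2)c1`, 400 nM
compound 2 `CCN(C/C=C/C#CC(C)(C)C)Cc1cccc(OC[Si](C)(C)c2ccc(C(N)=O)cc2)c1`, 5000 nM

Compound 2 stands at the highest of the two numbers in a functional assay on liver (Sus scrofa) for inhibition of squalene monooxygenase (Homo sapiens), using microsomes; on this read-out higher numbers stand for weaker inhibition and lower numbers for stronger inhibition; its nearest neighbour is compound 1, separated by a 13-fold higher number from compound 1 to compound 2 (1.10 log units; beyond the scatter), a change of carbamoyl for chloro on the aromatic carbon.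

Compound 3 `CCN(C/C=C/C#CC(C)(C)C)Cc1cccc(OC[Si](C)(C)c2ccc(C=O)cc2)c1` is not yet measured. It differs from compound 2 by hydrogen in place of amino on a carbonyl carbon. Going by the values given here, the only step that bears on this position is a 13-fold higher number from compound 1 to compound 2 (1.10 log units; beyond the scatter), which shows that exchange at this aromatic carbon moves the read-out by a large amount. Formyl keeps the carbonyl of compound 2 but loses the amino group, so a shift back toward compound 1 is expected, though not the full way.

Compound 3 is therefore expected to show a lower number than compound 2 in this assay, by about a 2.5-fold lower number from compound 2 to compound 3 (0.40 log units; beyond the scatter); the estimate for compound 3 is 2000 nM, with a range of 700 nM to 6000 nM.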

Compound 3, half-maximal inhibitory concentration: 100 nM
Compound 3: middle estimate off by 20-fold (1.30 log units), on the high side, outside the stated range (below it).
By their numbers in this assay, from the lowest: compound 3; then compound 1; then compound 2.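

In this assay the exchange of amino for hydrogen on the carbonyl carbon gives a 50-fold lower number from compound 2 to compound 3 (1.70 log units; beyond the scatter) and so the carbonyl being kept does not hold the read-out near that of the carbamoyl group. Formyl also passes chloro on the same aromatic carbon, with a 4.0-fold lower number from compound 1 to compound 3 (0.60 log units; beyond the scatter) as the step, which places chloro between formyl and carbamoyl rather than at the low end of the three groups. No supporting data accompany these numbers to account for the gap between formyl and carbamoyl.

As far as these compounds go, whether the low number stays with other carbonyl groups, such as acetyl or a methyl ester, or goes with a hydroxymethyl group or a nitrile at this carbon remains open. An N-methyl carbamoyl group would show whether replacing one amide hydrogen alone moves the read-out away from that of carbamoyl.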